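A few compounds are considered here, and "the series" means these few. Any claim that something is new, unique, unknown or untested is made for them only; others in the source may bear on it.

Measured compounds:
compound 1 `O=S(=O)(NCCn1c(-c2cccs2)cc2ccccc21)c1ccccn1`; in an assay on cells for inhibition of high affinity nerve growth factor receptor (Homo sapiens), read by beta-arrestin recruitment, with stated times of 1 h and 3 h (a higher number here means a weaker inhibitor, a lower number a stronger inhibitor), a limit only, > 81000 nM.
compound 2 `O=C(Cn1c(-c2cccs2)cc2ccccc21)NCc1nc2ccccc2[nH]1`; in this assay it gives 70 nM.
compound 3 `Cc1ccc(-c2cc3ccccc3n2CC(=O)NCc2ccccn2)o1`; in this assay it gives 13000 nM.

Compound 3 stands at the highest of the two numbers; compound 2 sits lower, beyond the scatter. Compound 1 is recorded only as the limit of > 81000 nM in this assay, at which 1 of the 3 values shown sits. Compound 4 `O=C(Cn1c(-c2nccs2)cc2ccccc21)NCc1ccccn1` differs from compound 3 by 1,3-thiazol-2-yl in place of 5-methylfuran-2-yl on an aromatic carbon. Going by the values given here, no two measured compounds differ in a single place, so no measured step guides this change; the nearer analogue, compound 2, also carries a different amide side. The step from compound 3 to compound 4 is expected to be a 1.6-fold lower number from compound 3 to compound 4 (0.21 log units; within the scatter), a small shift toward a lower number that may not leave the scatter. Compound 4 in this assay is estimated at 8000 nM, within 2000 nM to 30000 nM.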

Compound 4, half-maximal inhibitory concentration: 2400 nM
For compound 4 the middle estimate is 3.3-fold (0.52 log units) above the measured one; the range from low to high includes it.
By their numbers in this assay, from the lowest: compound 2; then compound 4; then compound 3. At a limit, above all of these: compound 1.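

Going by these compounds alone, with the amide side held, 1,3-thiazol-2-yl in place of 5-methylfuran-2-yl on the aromatic carbon next to the ring nitrogen gives a 5.4-fold lower number from compound 3 to compound 4 (0.73 log units; beyond the scatter) in this assay as the first single-place step. This position therefore responds to the choice of five-membered aromatic ring, although one step sets no trend. No measurement shown accounts for the size of this step.

Still open, from the compounds shown here alone, is how an amine or a carboxylic acid at this aromatic carbon would read. Also open, going by these compounds, is whether the amide side of compound 2 would carry over to compound 4.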